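A few compounds are considered here, and "the series" means these few. Any claim that something is new, unique, unknown or untested is made for them only; others in the source may bear on it.

Measured in a functional assay on HL-60 cells (Homo sapiens) for antiproliferative activity, read by XTT assay, with a stated time of 72 h; on this read-out higher numbers stand for weaker inhibition and lower numbers for stronger inhibition:

- Compound 1 `C#Cc1cn([C@@H]2O[C@H](CO)[C@@H](O)[C@H]2O)c2ncnc(SC)c12`: 50 nM
- Compound 2 `C#Cc1cn([C@@H]2O[C@H](CO)[C@@H](O)[C@H]2O)c2ncnc(N(C)C)c12`: 290 nM
- Compound 3 `Cc1ncnc2c1c(-c1cccs1)cn2[C@@H]1O[C@H](CO)[C@@H](O)[C@H]1O`: 5730 nM

Compound 3 is the weakest of the three, with the highest number, and both compound 2 and compound 1 lie far below it. Compound 4 `C#Cc1cn([C@@H]2O[C@H](CO)[C@@H](O)[C@H]2O)c2ncnc(C)c12` replaces thiophen-2-yl with ethynyl on an aromatic carbon: ethynyl in place of thiophen-2-yl on an aromatic carbon. Among the compounds with values here, no measured step makes this exact swap. Within the data shown here, the only measured step, a 5.8-fold higher number from compound 1 to compound 2 (0.76 log units; beyond the scatter), changes a different group, but it suggests how far that group can move the number while ethynyl stays. Compound 4 shares ethynyl with compound 1 and compound 2, and it keeps the other group of compound 3, so a large fall is expected. The estimated change is a 48-fold lower number from compound 3 to compound 4 (1.68 log units; beyond the scatter), towards stronger inhibition. For compound 4 the expected value is 120 nM, within an estimated range of 25 nM to 600 nM.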

Compound 4, half-maximal inhibitory concentration: 1110 nM
Compound 4: the middle estimate sits 9.3-fold (0.97 log units) below what was measured; the measured number lies above the stated range.
By their numbers in this assay, from the lowest: compound 1; then compound 2; then compound 4; then compound 3.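

In this assay, within the data shown here, ethynyl in place of thiophen-2-yl gives a 5.2-fold lower number from compound 3 to compound 4 (0.71 log units; beyond the scatter) with methyl kept, the first direct reading of this swap on this aromatic carbon. With ethynyl kept, the other substituted carbon also moves the number: methyl in place of dimethylamino gives a 3.8-fold higher number from compound 2 to compound 4 (0.58 log units; beyond the scatter) and methyl in place of methylsulfanyl gives a 22-fold higher number from compound 1 to compound 4 (1.35 log units; beyond the scatter) as a large step. Nothing available explains these shifts. Open remains how a nitrile or a longer alkyne chain on this carbon would compare, and whether thiophen-2-yl would cost as much with methylsulfanyl at the other place.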